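A few compounds are considered here, and "the series" means these few. Any claim that something is new, unique, unknown or untested is made for them only; others in the source may bear on it.

Compound 1 `NC(=O)c1cc(Cl)ccc1NC(=O)/C=C/c1ccccc1Br`: 49%
Compound 2 `NC(=O)c1cc(Br)ccc1NC(=O)/C=C/c1ccc(Cl)cc1`: 22%

Among the compounds with values here, in a functional assay on K562 cells (Homo sapiens) for antiproliferative activity, read by trypan blue exclusion, with a stated time of 48 h, tested at 10 uM (on this read-out lower numbers stand for less inhibition of growth and higher numbers for more inhibition of growth at the one concentration tested), compound 2 gives 22%, the lower of the two numbers so far, and the gap up to compound 1 lies beyond the usual scatter. The next compound, compound 3 `NC(=O)c1cc(Br)ccc1NC(=O)/C=C/c1ccccc1Br`, has not yet been measured. It carries 2-bromophenyl in place of 4-chlorophenyl on a double-bonded chain carbon bound to a double-bonded chain carbon. Compound 1 also carries 2-bromophenyl and gives 49%, which points to a rise in this assay. No single change has yet been tested alone, so this reasoning remains uncertain. A rise beyond the scatter is expected, estimated as a number 20 percentage points higher from compound 2 to compound 3 (beyond the scatter). For compound 3 the expected value is 42%, with an estimated range of 25% to 60%.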

Compound 3, percent growth inhibition at one concentration: 46.2%
Compound 3: middle estimate off by 4.2 percentage points, on the low side; low and high end bracket the measured number.
By their numbers in this assay, from the lowest: compound 2; then compounds 3 and 1 (each within the scatter of the next).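

In this assay, the step from 4-chlorophenyl to 2-bromophenyl on a double-bonded chain carbon bound to a double-bonded chain carbon gives a number 24.2 percentage points higher from compound 2 to compound 3 (beyond the scatter) with the rest of the molecule unchanged, so the group at this place clearly affects the read-out. Bromo in place of chloro on an aromatic carbon gives a number 2.8 percentage points lower from compound 1 to compound 3 (within the scatter) and therefore does not separate these two compounds in this read-out. Nothing available explains the rise at the chain position.

The rise combines two differences, the halogen and where it sits on the phenyl group, so it cannot be assigned to either one alone. From the compounds shown here alone, how 2-chlorophenyl or 4-bromophenyl would behave at this place remains open, as does the effect of a phenyl group bearing an amine or a carboxylic acid.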